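The source may report more compounds than this note shows. Statements on the series, on what has been measured and on what is new or still open speak of the compounds shown alone.

Measured compounds, read in a functional assay on HL-60 cells (Homo sapiens) for antiproliferative activity, read by MTT assay, with a stated time of 72 h; a higher number here means a weaker inhibitor, a lower number a stronger inhibitor:
compound 1 `CNc1nc(-c2cc(OC)c(OC)c(OC)c2)c(-c2ccc(OC)cc2)s1` gives 27.3 nM
compound 2 `CCOc1ccc(-c2sc(NC)nc2-c2cc(OC)c(OC)c(OC)c2)cc1` gives 1.8 nM
compound 3 `COc1ccc(-c2sc(C)nc2-c2cc(OC)c(OC)c(OC)c2)cc1` gives 3430 nM

Two changes have been measured so far. From compound 1 to compound 2 the change is methyl in place of hydrogen on a saturated chain carbon bound to an oxygen on an aromatic ring and the step in this assay is a 15-fold lower number from compound 1 to compound 2 (1.18 log units; beyond the scatter). From compound 1 to compound 3 the change is methyl in place of methylamino on an aromatic carbon and the step is a 130-fold higher number from compound 1 to compound 3 (2.10 log units; beyond the scatter); compound 3 thus carries the highest number of the three.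

Compound 4 `CCOc1ccc(-c2sc(C)nc2-c2cc(OC)c(OC)c(OC)c2)cc1` is not yet measured. It differs from compound 3 by methyl in place of hydrogen on a saturated chain carbon bound to an oxygen on an aromatic ring. The place of this change reads word for word the same as for the change from compound 1 to compound 2, so it is the same change, made on a different core: the two cores differ as told by methyl in place of methylamino on an aromatic carbon.

Going by the values given here, the only measured instance of this change is the step from compound 1 to compound 2, and it is large. As far as these compounds go, there is no second instance on either core, so it remains open whether the step carries over in full size to the core of compound 3. Among the compounds with values here, on the one measured step, the expectation for compound 4 in this assay is a step of an 8.6-fold lower number from compound 3 to compound 4 (0.93 log units; beyond the scatter), with the width of the range reflecting that it rests on a single pair. The expected value for compound 4 is 400 nM, between 100 nM and 2000 nM.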

Compound 4, half-maximal inhibitory concentration: 253 nM
For compound 4 the middle estimate is 1.6-fold (0.20 log units) above the measured one; the measured number falls inside the stated range.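

In this assay the change from 4-methoxyphenyl to 4-ethoxyphenyl gives a 14-fold lower number from compound 3 to compound 4 (1.13 log units; beyond the scatter) on the core of compound 3, and it keeps its size from the core of compound 1: the same change on two cores in this assay, a 15-fold lower number (1.18 log units; beyond the scatter) from compound 1 to compound 2 and a 14-fold lower number (1.13 log units; beyond the scatter) from compound 3 to compound 4, 1.1-fold (0.05 log units) apart, within the scatter of two such steps.

Read the other way round, methyl in place of methylamino on an aromatic carbon gives a 140-fold higher number from compound 2 to compound 4 (2.15 log units; beyond the scatter) with the 4-ethoxyphenyl group in place, and this step also keeps its size from the one measured with 4-methoxyphenyl: the same change on two cores in this assay, a 130-fold higher number (2.10 log units; beyond the scatter) from compound 1 to compound 3 and a 140-fold higher number (2.15 log units; beyond the scatter) from compound 2 to compound 4, 1.1-fold (0.05 log units) apart, within the scatter of two such steps.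

Within these compounds, then, the two changes act independently of each other and the ethoxy step carries over in full, but this rests on a single pair of cores in a single cell line, so it sets no rule for other cores and gives no reason for the size of either step.

Still open, as far as these compounds go, is whether a longer chain, such as propoxy or butoxy in place of ethoxy, continues the gain seen from methoxy to ethoxy or reverses it. Equally open, from the compounds shown here alone, is how a primary amine or a dimethylamino group would compare with methylamino on the shared core, and whether the ethoxy step would hold there as well.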